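The compounds below may be only part of what the source reports. "The series", "measured", "known", "first", "only" and "open" are said of these compounds alone.

Measured in a functional assay, read by spectrophotometry, with a stated time of 5 min; a higher number here means a weaker inhibitor, a lower number a stronger inhibitor:
- compound 1 `CCOc1cc(/C=C/C(=O)C(=Cc2ccc(O)c(OC)c2)C(=O)/C=C/c2ccc(O)c(OCC)c2)ccc1O`: 5360 nM
- compound 2 `CCOc1cc(/C=C/C(=O)C(=Cc2ccc(OC)c(OC)c2)C(=O)/C=C/c2ccc(O)c(OCC)c2)ccc1O`: 11300 nM

Of these two, compound 2 has the higher number in this assay, which makes it the weaker inhibitor. Compound 3 `CCOc1cc(C=C(C(=O)/C=C/c2ccc(O)c(OCC)c2)C(=O)/C=C/c2ccc(O)c(OCC)c2)ccc1O` differs from it by 3-ethoxy-4-hydroxyphenyl in place of 3,4-dimethoxyphenyl on a double-bonded chain carbon bound to a double-bonded chain carbon. Among the compounds with values here, one measured step bears on this: a 2.1-fold higher number from compound 1 to compound 2 (0.32 log units; beyond the scatter), where methyl took the place of hydrogen on an oxygen on an aromatic ring. Compound 3 has that hydrogen back, so a step of similar size towards a lower number is expected. Within the data shown here, no measured step covers the ethoxy group. The expected change is a 2.3-fold lower number from compound 2 to compound 3 (0.35 log units; beyond the scatter). For compound 3 the estimate is 5000 nM, with an expected range of 2300 nM to 11000 nM.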

Compound 3, half-maximal inhibitory concentration: 5140 nM
Compound 3: middle estimate off by 1.0-fold (0.01 log units), on the low side, and the stated range covers the measured number.
By their numbers in this assay, from the lowest: compounds 3 and 1 (each within the scatter of the next); then compound 2.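

Going from methoxy to ethoxy on this ring adds a methyl on a saturated chain carbon bound to an oxygen and gives a 1.0-fold lower number from compound 1 to compound 3 (0.02 log units; within the scatter), so no effect of that methyl can be read. Replacing 3,4-dimethoxyphenyl with 3-ethoxy-4-hydroxyphenyl gives a 2.2-fold lower number from compound 2 to compound 3 (0.34 log units; beyond the scatter), so among these three, the lower numbers go with the ring hydroxyl that compound 1 and compound 3 carry and compound 2 lacks. No measurement here explains this pattern. Still open, from the compounds shown here alone, is whether a longer chain, such as propoxy, or an amine in place of that hydroxyl would fit this pattern.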